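The source may hold more compounds than are shown below. What is called first, only, known or untested is meant among the compounds shown, and "the series" means these compounds.

Compound 1, with the structure `COc1cc2c(cc1OC)C(=O)/C(=C/c1cccc(C)c1)CC2`, was tested in a functional assay on Jurkat cells (Homo sapiens) for antiproliferative activity, read by MTT assay (on this read-out lower numbers stand for stronger inhibition and higher numbers for weaker inhibition), and there compound 1 gives 17000 nM. Within the data shown here, it is the only compound in this small set with an actual number; the other value is a limit of the assay. Compound 2, with the structure `COc1cc2c(cc1OC)C(=O)/C(=C/c1ccc(O)c(C(=O)O)c1)CC2`, carries a hydroxyl and a carboxylic acid on its outer ring instead of the methyl, and in this assay compound 2 gives > 50000 nM, which is a limit of the assay and not a number. That reading sits at the limit of > 50000 nM in this assay, at which 1 of the 2 values shown sits. Among the measured compounds shown here, since the two compounds differ in more than one place, no single step between them is counted; their values only show that compound 1 gives a number while compound 2 does not.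

Compound 3, with the structure `COc1cc2c(cc1OC)C(=O)/C(=C/c1cc(C)cc(C)c1)CC2`, is not yet measured. It differs from compound 1 in one place: methyl in place of hydrogen on an aromatic carbon. For the measured compounds named here, with no measured step of this kind to lean on, the step of a 1.4-fold lower number from compound 1 to compound 3 (0.15 log units; within the scatter) is expected to be small, possibly within the scatter. In this assay compound 3 is therefore expected to give about 12000 nM, within a range from 4000 nM to 40000 nM.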

Compound 3, half-maximal inhibitory concentration: 4000 nM
Compound 3: the middle estimate sits 3.0-fold (0.48 log units) above what was measured; the measured number falls inside the stated range.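

The step shows that this place on the ring can take an added methyl without a loss: going from 3-methylphenyl to 3,5-dimethylphenyl in this assay gives a 4.3-fold lower number from compound 1 to compound 3 (0.63 log units; beyond the scatter). Among these compounds, this is the first comparison in the set that changes one thing only, so for the first time a difference in the numbers can be tied to a single group, and here it lies beyond the scatter, though it is modest in size. Nothing shown here explains why this second methyl goes with a lower number.

A single pair cannot tell whether the gain belongs to the methyl itself or whether other groups at this place, such as an ethyl chain, a chlorine atom or an amine, would give a similar, larger or opposite step. It also leaves open whether the step depends on the first methyl already on the ring, which a comparison with a plain phenyl ring on the same core could show, and whether the effect on these cells would carry over to other cell types.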